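This account rests on a few compounds, and the source may have more. Where it says the series, first, only, none or still open, it means among the compounds named here.

Working notes on the series. Of the compounds shown here, three have been measured in an ADME assay on Vero cells (Chlorocebus sabaeus) for cytotoxicity, read by MTT assay, with a stated time of 72 h; a lower number here means that less compound is tolerated, a higher number that more compound is tolerated. Compound 1 `O=C(COc1ccccc1C(=O)/C=C/c1ccc(Cl)cc1)NCCNc1ccnc2cc(Cl)ccc12` gives 4980 nM, compound 2 `COc1ccc(/C=C/C(=O)NCCNc2ccnc3cc(Cl)ccc23)cc1OC` gives 5600 nM and compound 3 `O=C(/C=C/c1ccc(Cl)cc1)NCCNc1ccnc2cc(Cl)ccc12` gives 6930 nM. Compound 1 stands within the scatter of compound 2 and of compound 3, so none of the three is set apart in this assay.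

Compound 4 `COc1ccc(/C=C/C(=O)c2ccccc2OCC(=O)NCCNc2ccnc3cc(Cl)ccc23)cc1OC` has not been measured. It differs from compound 1 by one change: 3,4-dimethoxyphenyl in place of 4-chlorophenyl on a double-bonded chain carbon bound to a double-bonded chain carbon. The same exchange of aryl groups separates compound 3 from compound 2, whose values in this assay sit within the scatter of each other. The step from compound 1 to compound 4 is therefore expected to be small, a 1.1-fold lower number from compound 1 to compound 4 (0.04 log units; within the scatter), with no direction beyond the scatter. Compound 4 is estimated at 4500 nM, within 2200 nM to 9000 nM.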

Compound 4, half-maximal cytotoxic concentration: 5310 nM
The estimate for compound 4 lay 1.2-fold (0.07 log units) below the measured number; the range from low to high includes it.
By their numbers in this assay, from the lowest: compounds 1, 4, 2 and 3 (each within the scatter of the next).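

On the core of compound 1, the exchange of 4-chlorophenyl for 3,4-dimethoxyphenyl on a double-bonded chain carbon bound to a double-bonded chain carbon gives, in this assay, a 1.1-fold higher number from compound 1 to compound 4 (0.03 log units; within the scatter) and so no separation. This position therefore takes up the larger entering group, with its two oxygen atoms, without a change beyond the scatter. No measurement here bears on the reason for this.

From the compounds shown here alone, whether an amine or a carboxylic acid on the same aryl ring would also stay within the scatter remains open. So does the effect of removing the aryl ring altogether.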